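Methoxy addition on a propyl analogue of an aryl sulfonate

A few compounds are considered here, and "the series" means these few. Any claim that something is new, unique, unknown or untested is made for them only; others in the source may bear on it.

Compound 1 `COc1cccc(OS(=O)(=O)c2ccc(N3CCN(C)C3=O)cc2)c1` gives 1600 nM in a functional assay on M21 cells (Homo sapiens) for antiproliferative activity, read by sulforhodamine B assay, with a stated time of 48 h; on this read-out higher numbers stand for weaker inhibition and lower numbers for stronger inhibition. Compound 2 `COc1cc(OC)cc(OS(=O)(=O)c2ccc(N3CCN(C)C3=O)cc2)c1` carries the difference methoxy in place of hydrogen on an aromatic carbon and gives 82 nM in this assay, a change of a 20-fold lower number from compound 1 to compound 2 (1.29 log units; beyond the scatter). Compound 3 `CCCN1CCN(c2ccc(S(=O)(=O)Oc3cccc(OC)c3)cc2)C1=O` differs from compound 1 by ethyl in place of hydrogen on a saturated chain carbon bound to an amide-type nitrogen in a ring. In this assay compound 3 gives 10000 nM, a change of a 6.3-fold higher number from compound 1 to compound 3 (0.80 log units; beyond the scatter). Compound 4 `CCCN1CCN(c2ccc(S(=O)(=O)Oc3ccc(OC)c(OC)c3)cc2)C1=O` is not yet measured; it differs from compound 3 by methoxy in place of hydrogen on an aromatic carbon. This is the same kind of change as that from compound 1 to compound 2, but the surroundings differ: there the entering methoxy was meta to a large group and meta to a methoxy group, here it is ortho to a methoxy group and para to a large group. A smaller gain is therefore expected, a 3.3-fold lower number from compound 3 to compound 4 (0.52 log units; beyond the scatter), resting on the earlier step of a 20-fold lower number from compound 1 to compound 2 (1.29 log units; beyond the scatter) and the weak starting point of compound 3 at 10000 nM. Compound 4 is estimated at 3000 nM.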

Compound 4, half-maximal inhibitory concentration: 28000 nM
For compound 4 the middle estimate is 9.3-fold (0.97 log units) below the measured one; measured number above the stated range.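

In this assay the methoxy addition gives a 2.8-fold higher number from compound 3 to compound 4 (0.45 log units; beyond the scatter), so the earlier gain did not carry over from one core to the other, in size or in direction: the same change on two cores in this assay, a 20-fold lower number (1.29 log units; beyond the scatter) from compound 1 to compound 2 and a 2.8-fold higher number (0.45 log units; beyond the scatter) from compound 3 to compound 4, 55-fold (1.74 log units) apart, beyond the scatter of two such steps

The two steps differ in the core and also in where the methoxy enters, here ortho to a methoxy group and para to a large group, so this pair cannot separate those two influences. Among the compounds shown here, it shows that a gain from this change on one core cannot be assumed on another, but it rests on only two steps and gives no general rule.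

As far as these compounds go, whether a methoxy placed as in compound 2 would bring a gain on the core of compound 3 remains open. So does the outcome with a butyl chain in place of the propyl chain, or with an amine in place of the entering methoxy.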